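Removing both methoxy groups from the aryl hydrazone unit

The source may hold more compounds than are shown below. What is called first, only, known or untested is meant among the compounds shown, and "the series" means these compounds.

Compound 1 `CN(C)CCn1cnnc1-c1cc(Oc2ccc(NC(=O)N/N=C/c3ccc(Cl)cc3Cl)cc2F)ccn1`: 130 nM
Compound 2 `CN(C)CCn1cnnc1-c1cc(Oc2ccc(NC(=O)N/N=C/c3cc(C(C)(C)C)cc(C(C)(C)C)c3O)cc2F)ccn1`: 590 nM
Compound 3 `COc1ccc(/C=N/NC(=O)Nc2ccc(Oc3ccnc(-c4nncn4CCN(C)C)c3)c(F)c2)c(OC)c1`: 1570 nM

Three compounds sharing one core were measured in a functional assay on NCI-H460 cells (Homo sapiens) for cytotoxicity, read by MTT assay, with a stated time of 72 h; on this read-out lower numbers stand for stronger inhibition and higher numbers for weaker inhibition. Compound 3 gives 1570 nM, the highest number of the three. Its nearest neighbour is compound 2, which gives 590 nM; furthest away is compound 1, which gives 130 nM. Both gaps lie beyond the scatter, so compound 3 is the weakest of the measured set.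

Compound 4 `CN(C)CCn1cnnc1-c1cc(Oc2ccc(NC(=O)N/N=C/c3ccccc3)cc2F)ccn1` has not yet been measured. It differs from compound 3 in one place: phenyl in place of 2,4-dimethoxyphenyl on a carbon with a double bond to nitrogen. Among the compounds with values here, the only measured step that bears on this change is the one at the same position, where a 12-fold higher number from compound 1 to compound 3 (1.08 log units; beyond the scatter). That step shows the aryl group on the carbon with a double bond to nitrogen can move the number strongly in this assay. Within the data shown here, no measured step removes the substituents altogether, so the direction for a bare phenyl rests on compound 1 alone, whose value 130 nM suggests the dimethoxy pattern of compound 3 is unfavourable.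

Compound 4 is therefore expected to show a lower number than compound 3, with an estimated step of a 3.1-fold lower number from compound 3 to compound 4 (0.50 log units; beyond the scatter). The estimate for compound 4 in this assay is 500 nM, with a range from 150 nM to 1600 nM.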

Compound 4, half-maximal inhibitory concentration: 1780 nM
The estimate for compound 4 lay 3.6-fold (0.55 log units) below the measured number, and the stated range ends below it.
By their numbers in this assay, from the lowest: compound 1; then compound 2; then compounds 3 and 4 (each within the scatter of the next).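

In this assay, the two methoxy groups turn out to make no readable difference at the carbon with a double bond to nitrogen: phenyl in place of 2,4-dimethoxyphenyl gives only a step within the scatter (a 1.1-fold higher number from compound 3 to compound 4 (0.05 log units; within the scatter)). The earlier compounds shown here could not show this, since the large step between compound 1 and compound 3 might have reflected a penalty from the methoxy groups, yet the bare phenyl ring stands just as far from the dichlorinated one (a 14-fold higher number from compound 1 to compound 4 (1.14 log units; beyond the scatter)). Within these three compounds, the low number therefore goes with the 2,4-dichlorophenyl of compound 1, not with a loss caused by the methoxy groups in compound 3. Nothing at hand gives a measured reason for this difference.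

From the compounds shown here alone, whether a single chlorine would be enough remains open, as does whether a bromine or a trifluoromethyl group on the phenyl ring would bring the number close to that of compound 1 (130 nM). The compounds shown also leave open how an amine or a carboxylic acid on that ring would behave in this assay.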